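This account rests on a few compounds, and the source may have more. Where it says the series, first, only, none or still open, it means among the compounds named here.

Compound 1, `COc1ccc([C@@H]2C(c3ccc(C)s3)C(=O)N2c2cc(OC)c(OC)c(OC)c2)cc1`, was tested in a functional assay on MCF7 cells (Homo sapiens) for antiproliferative activity, read by MTT assay (a higher number here means a weaker inhibitor, a lower number a stronger inhibitor), and gave 250 nM. Compound 2, `COc1ccc([C@@H]2[C@@H](c3cccs3)C(=O)N2c2cc(OC)c(OC)c(OC)c2)cc1O`, was examined in the same assay, and compound 2 gave 7 nM. Among the two measured compounds, compound 1 therefore stands at the highest number, while the number for compound 2 is far lower, a gap that lies well beyond the ordinary scatter of such measurements.

The piece now follows the path from compound 1 to compound 3, `COc1ccc([C@@H]2C(c3cc4ccccc4s3)C(=O)N2c2cc(OC)c(OC)c(OC)c2)cc1`. The change is 1-benzothiophen-2-yl in place of 5-methylthiophen-2-yl on a saturated ring carbon. For the measured compounds named here, no measured pair differing only in this way is available, so the size of the step must be judged without a direct precedent.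

A modest step, if any, is expected, most likely toward a weaker inhibitor rather than a stronger one, and it may well stay within the scatter. The expected shift in this assay is a 1.6-fold higher number from compound 1 to compound 3 (0.20 log units; within the scatter). On that basis, compound 3 is estimated to give about 400 nM in this assay, with a plausible range from 100 nM to 2000 nM.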

Compound 3, half-maximal inhibitory concentration: 850 nM
Estimate against measurement, compound 3: 2.1-fold (0.33 log units) below, within the range that was stated.
By their numbers in this assay, from the lowest: compound 2; then compound 1; then compound 3.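

In this assay, for the compounds shown here, putting 1-benzothiophen-2-yl in place of 5-methylthiophen-2-yl produces a 3.4-fold higher number from compound 1 to compound 3 (0.53 log units; beyond the scatter) and gives the first comparison here in which only one place differs. It shows that this saturated ring carbon of the four-membered ring responds to the group it carries, even though both groups hold a five-membered aromatic ring with 1 hetero atom and match in hydrogen-bond donors, hydrogen-bond acceptors and net charge. The added six-membered aromatic ring of carbon only, and the larger heavy-atom count that comes with it, go with a weaker inhibitor here, though this single step cannot establish a trend, and nothing measured here accounts for its direction.

The compounds shown leave open how this ring carbon would respond to a group of a different kind, such as a primary amine or a carboxylic acid on the thiophene ring. Compound 2 differs from compound 1 and from compound 3 in more than one place, so its much lower number cannot be assigned to any single change.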